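Swapping a Tert-Butyl for a Hydroxypropyl

The compounds below may be only part of what the source reports. "The series", "measured", "known", "first", "only" and "open" are said of these compounds alone.

Compound 1 `Cc1ccc(OCC(=O)N(Cc2cccs2)C(C)(C)C)cc1` is the weaker of the two measured compounds: in an assay on HEK293 cells for agonist activity at transient receptor potential cation channel subfamily M member 8 (Homo sapiens), read by fluorescence and calcium flux, with a stated time of 15 min (on this read-out higher numbers stand for an effect only at larger amounts of compound and lower numbers for an effect already at smaller amounts), compound 1 gives 11000 nM, whereas compound 2 `CCN(Cc1cccs1)C(=O)/C=C/c1ccc(C)cc1` gives 2 nM, a gap far beyond the usual scatter. Compound 3 `Cc1ccc(OCC(=O)N(CCCO)Cc2cccs2)cc1` differs from compound 1 by a single exchange: 3-hydroxypropyl in place of tert-butyl on an amide-type nitrogen. Among the measured compounds shown here, no measured pair shows this exact change, so its effect can only be guessed. A modest shift toward smaller concentrations is expected in this assay, with the step of a 2.2-fold lower number from compound 1 to compound 3 (0.34 log units; beyond the scatter), though it may also stay within the scatter. Compound 3 is estimated at 5000 nM, within 1000 nM to 30000 nM.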

Compound 3, half-maximal effective concentration: 3000 nM
The estimate for compound 3 lay 1.7-fold (0.22 log units) above the measured number; measured number inside the range.
By their numbers in this assay, from the lowest: compound 2; then compound 3; then compound 1.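

In this assay, 3-hydroxypropyl in place of tert-butyl on the amide-type nitrogen gives a 3.7-fold lower number from compound 1 to compound 3 (0.56 log units; beyond the scatter). Among the compounds shown here, this is the first step measured at this position, and it shows that the number responds to the group placed there, though only modestly. Nothing available explains why the number moves. On these data alone, it remains open whether the hydroxyl oxygen matters or whether replacing the tert-butyl alone accounts for the step. A plain propyl group would help separate the two, while an amine or a longer chain would show how far this position tolerates other groups.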